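The source may hold more compounds than are shown below. What is called first, only, known or untested is meant among the compounds shown, and "the series" means these compounds.

Measured in a functional assay for agonist activity at P2Y purinoceptor 2 (Homo sapiens), read by FLIPR; on this read-out lower numbers stand for an effect already at smaller amounts and higher numbers for an effect only at larger amounts of compound:
compound 1, `O=c1c2ccccc2ccn1[C@@H]1O[C@H](COP(=O)(O)OP(=O)(O)OP(=O)(O)O)[C@@H](O)[C@H]1O`, 31 nM
compound 2, `O=c1c2occc2ccn1[C@@H]1O[C@H](COP(=O)(O)OP(=O)(O)OP(=O)(O)O)[C@@H](O)[C@H]1O`, 221 nM
compound 3, `Cc1ccc2c(=O)n([C@@H]3O[C@H](COP(=O)(O)OP(=O)(O)OP(=O)(O)O)[C@@H](O)[C@H]3O)ccc2c1`, 35 nM

Compound 3 gives the second highest of these three numbers; compound 1 sits within the scatter of it, while compound 2 gives a number beyond the scatter above it. Compound 4 is `O=c1c2ccc(F)cc2ccn1[C@@H]1O[C@H](COP(=O)(O)OP(=O)(O)OP(=O)(O)O)[C@@H](O)[C@H]1O`; it differs from compound 3 by fluoro in place of methyl on an aromatic carbon. Among the compounds with values here, only one measured step touches this aromatic carbon: a 1.1-fold higher number from compound 1 to compound 3 (0.05 log units; within the scatter). Within the data shown here, no measured step involves fluoro at all, so the comparison rests on that single change. Because a 1.1-fold higher number from compound 1 to compound 3 (0.05 log units; within the scatter) stayed within the scatter, the expected change is no change at the digits printed from compound 3 to compound 4 (within the scatter). Compound 4 is therefore expected to give 35 nM in this assay, with a range from 14 nM to 90 nM.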

Compound 4, half-maximal effective concentration: 77 nM
For compound 4 the middle estimate is 2.2-fold (0.34 log units) below the measured one; measured number inside the range.
By their numbers in this assay, from the lowest: compounds 1 and 3 (each within the scatter of the next); then compound 4; then compound 2.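

In this assay, this aromatic carbon proves sensitive to what it carries: fluoro in place of hydrogen brings a 2.5-fold higher number from compound 1 to compound 4 (0.40 log units; beyond the scatter) and fluoro in place of methyl brings a 2.2-fold higher number from compound 3 to compound 4 (0.34 log units; beyond the scatter) even though methyl in place of hydrogen had stayed within the scatter. A silent step with one group therefore says little about the next group at the same carbon. Nothing available explains this difference between methyl and fluoro.

On these data alone, whether larger shifts occur with an amine, a methoxy group or a carboxylic acid on this carbon remains open.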